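This account rests on a few compounds, and the source may have more. Where it says the series, first, only, none or still open, it means among the compounds named here.

Of the compounds shown here, two have already been measured in an assay on isolated protein for inhibition of Amine oxidase [flavin-containing] A (Homo sapiens), read by spectrophotometry; on this read-out higher numbers stand for weaker inhibition and lower numbers for stronger inhibition. Compound 1 `COc1cc(/C(C)=N/Nc2nc3ccccc3nc2Cc2ccccc2)cc(OC)c1OC` gives 29 nM, and compound 2 `C(=N/Nc1nc2ccccc2nc1Cc1ccccc1)\c1ccccc1` gives 81 nM. Of these two numbers, compound 2 stands at the higher end, and the gap between compound 1 and compound 2 lies beyond the usual scatter of this assay; the two structures differ in more than one place, so nothing can be said about which difference carries that gap.

Compound 3 `COc1ccc(/C=N/Nc2nc3ccccc3nc2Cc2ccccc2)cc1` is the next candidate. It differs from compound 2 in a single place: methoxy in place of hydrogen on an aromatic carbon. Among the measured compounds shown here, no directly comparable step between measured compounds is available. Since compound 1, the compound with methoxy groups on that ring, gives the lower number 29 nM, a modest lowering is expected. The step expected here is a 1.6-fold lower number from compound 2 to compound 3 (0.21 log units; within the scatter). Compound 3 is thus expected to give about 50 nM, within a range from 20 nM to 130 nM.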

Compound 3, half-maximal inhibitory concentration: 63 nM
Compound 3: the middle estimate sits 1.3-fold (0.10 log units) below what was measured, and the stated range covers the measured number.
By their numbers in this assay, from the lowest: compound 1; then compounds 3 and 2 (each within the scatter of the next).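

In this assay, methoxy on an aromatic carbon para to a large group gives a 1.3-fold lower number from compound 2 to compound 3 (0.11 log units; within the scatter), a step within the scatter, so the assay does not tell compound 3 from compound 2. This is the first change in a single place among the compounds shown, and it indicates that, at this position, going from phenyl to 4-methoxyphenyl brings no loss or gain that this read-out can resolve. Nothing measured here offers an explanation for this result.

As far as these compounds go, whether the same position would respond differently to an amine, a carboxylic acid or a longer chain remains open. Among the compounds shown here, compound 1 differs from compound 3 in more than one place, so no single step yet shows which of those differences matters.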